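Swapping the arylpiperazine headgroup on a potent pyridazinone

The source may hold more compounds than are shown below. What is called first, only, known or untested is meant among the compounds shown, and "the series" means these compounds.

Three compounds were measured in an assay on isolated protein for binding affinity to Alpha-1D adrenergic receptor (Homo sapiens), read by radioligand binding; on this read-out lower numbers stand for stronger inhibition and higher numbers for weaker inhibition. Compound 1 `COc1ccc(Cl)cc1N1CCN(CCCCNc2c(C(C)=O)c(C)nn(C)c2=O)CC1` gives 5.96 nM, and compound 2 `COc1ccccc1N1CCN(CCNc2cc(-c3ccccc3)nn(C)c2=O)CC1` gives 11.8 nM. Compound 3 `COc1ccc(Cl)cc1N1CCN(CCNc2c(C(C)=O)c(-c3ccccc3)nn(C)c2=O)CC1` gives 0.41 nM, the lowest of the three numbers and beyond the scatter from both others. Compound 4 `CC(=O)c1c(-c2ccccc2)nn(C)c(=O)c1NCCN1CCN(c2ccccc2F)CC1` is not yet measured in this assay; it differs from compound 3 by 2-fluorophenyl in place of 5-chloro-2-methoxyphenyl on an amine nitrogen in a ring. Going by the values given here, no measured pair shows this exact change, so the expected step rests on compound 3 alone. It is estimated that the change costs affinity, with a step from compound 3 to compound 4 of a 7.3-fold higher number from compound 3 to compound 4 (0.86 log units; beyond the scatter) in this assay. Compound 4 is expected to give 3 nM in this assay, within a range from 0.8 nM to 12 nM.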

Compound 4, inhibition constant: 0.49 nM
Beside the measured number, compound 4's estimate is 6.1-fold (0.79 log units) above it, outside the stated range (below it).
By their numbers in this assay, from the lowest: compounds 3 and 4 (each within the scatter of the next); then compounds 1 and 2 (each within the scatter of the next).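

In this assay, the step is a 1.2-fold higher number from compound 3 to compound 4 (0.08 log units; within the scatter), so 2-fluorophenyl on this amine nitrogen in a ring reads the same as 5-chloro-2-methoxyphenyl on this core. The chlorine and methoxy are therefore not required here for a sub-nanomolar number, and the entering group has fewer heavy atoms and no hydrogen-bond acceptor. No evidence is available to explain why the two groups read alike. From the compounds shown here alone, it remains open whether a plain phenyl or a 2-pyridyl group on that nitrogen would also hold this affinity, and whether 2-fluorophenyl would do so with a butyl chain.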